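Swapping a methoxy for a bromo on the amide aryl ring

The source may hold more compounds than are shown below. What is called first, only, known or untested is meant among the compounds shown, and "the series" means these compounds.

Compound 1 `O=C(COc1ccc2cc(/C=C3/SC(=O)NC3=O)ccc2c1)Nc1ccccc1` is the reference in an assay on isolated protein for inhibition of histone deacetylase 8 (Homo sapiens), with a stated time of 1 h (a higher number here means a weaker inhibitor, a lower number a stronger inhibitor), where compound 1 gives 4500 nM. Compound 2 `COc1ccc(NC(=O)COc2ccc3cc(/C=C4/SC(=O)NC4=O)ccc3c2)cc1` carries a methoxy on the aromatic carbon that is unsubstituted in compound 1. In this assay compound 2 gives > 50000 nM, which is a limit of the assay and not a number; compound 2 therefore stands at the weak end of what has been measured here (the limit of > 50000 nM in this assay, at which 1 of the 2 values shown sits). Compound 3 `O=C(COc1ccc2cc(/C=C3/SC(=O)NC3=O)ccc2c1)Nc1ccc(Br)cc1` has not yet been measured; it differs from compound 2 as follows: bromo in place of methoxy on an aromatic carbon. For the measured compounds named here, the one measured step that bears on this change is an at least 11-fold higher number from compound 1 to compound 2 (1.04 log units; beyond the scatter), showing that a methoxy at this place on an aromatic carbon weakens inhibition markedly. A bromo at the same position, para to a large group, is expected to sit between those two outcomes. For compound 3 the estimate is 15000 nM, within 3000 nM to 50000 nM, meaning a step of an at least 3.3-fold lower number from compound 2 to compound 3 (0.52 log units; beyond the scatter) is expected.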

Compound 3, half-maximal inhibitory concentration: 16000 nM
For compound 3 the middle estimate is 1.1-fold (0.03 log units) below the measured one, within the range that was stated.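

Replacing methoxy with bromo at this position gives an at least 3.1-fold lower number from compound 2 to compound 3 (0.49 log units; beyond the scatter), so the loss of inhibition depends on which group sits here and not merely on this carbon carrying a group. Bromo in place of hydrogen still gives a 3.6-fold higher number from compound 1 to compound 3 (0.55 log units; beyond the scatter), which leaves compound 1 the strongest inhibitor of the three in this assay. The step from methoxy to bromo rests on a limit of the assay for compound 2, not on a number: the limit of > 50000 nM in this assay, at which 1 of the 3 values shown sits.

From the compounds shown here alone, whether any group at this position can match or improve on hydrogen remains open, and a fluorine, an amine or a carboxylic acid here would test that. Going by these compounds, the true gap between methoxy and bromo also remains unknown, as does the effect of bromo on another carbon of this ring.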